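Swapping a sulfonamide substituent for a morpholine ring

This account rests on a few compounds, and the source may have more. Where it says the series, first, only, none or still open, it means among the compounds named here.

Three compounds sharing one core were measured in a functional assay on the whole organism (aorta) with Rattus norvegicus as the target; on this read-out lower numbers stand for smaller maximal responses and higher numbers for larger maximal responses:

compound 1, `CC(C)NS(=O)(=O)c1ccc2c(c1)C(n1ccccc1=O)=CC(C)(C)O2`, giving 76.9%
compound 2, `CC1(C)C=C(n2ccccc2=O)c2cc(S(=O)(=O)Nc3ccc([N+](=O)[O-])cc3)ccc2O1`, giving 82.2%
compound 3, `CN(C)S(=O)(=O)c1ccc2c(c1)C(n1ccccc1=O)=CC(C)(C)O2`, giving 78.3%

The three differ only in the group attached to the sulfonyl sulfur. The step of a number 1.4 percentage points higher from compound 1 to compound 3 (within the scatter) and the step of a number 5.3 percentage points higher from compound 1 to compound 2 (within the scatter) both stay within the scatter, so compound 1 sits alongside the other two rather than apart from them; none of the three can be called more or less active than another.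

Compound 4, `CC1(C)C=C(n2ccccc2=O)c2cc(S(=O)(=O)N3CCOCC3)ccc2O1`, is not yet measured. It differs from compound 1 in one place: morpholin-4-yl in place of isopropylamino on a sulfonyl sulfur. Among the compounds with values here, the steps that bear on this change are those that also alter the group on the sulfonyl sulfur: a number 1.4 percentage points higher from compound 1 to compound 3 (within the scatter), a number 3.9 percentage points lower from compound 2 to compound 3 (within the scatter) and a number 5.3 percentage points higher from compound 1 to compound 2 (within the scatter). Each of them is within the scatter, whether the group entering is small or carries a ring. With three such exchanges all leaving this assay unmoved, the expected step from compound 1 to compound 4 is a number 2.1 percentage points higher from compound 1 to compound 4 (within the scatter), that is, none beyond the scatter. Compound 4 is therefore estimated to give 79% in this assay, with a range from 70% to 88%.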

Compound 4, largest response reached (Emax), in percent of the reference or control that the assay uses: 75.5%
Estimate against measurement, compound 4: 3.5 percentage points above; the range from low to high includes it.
By their numbers in this assay, from the lowest: compounds 4, 1, 3 and 2 (each within the scatter of the next).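

Placing a non-aromatic ring on the sulfonyl sulfur does not set compound 4 apart from the other three in this assay: the comparisons read a number 1.4 percentage points lower from compound 1 to compound 4 (within the scatter) and a number 2.8 percentage points lower from compound 3 to compound 4 (within the scatter) and, for the largest gap, a number 6.7 percentage points lower from compound 2 to compound 4 (within the scatter) ( all three printed as within the scatter ). In the exchange of isopropylamino for morpholin-4-yl, the group on the sulfur loses its hydrogen-bond donor, gains a hydrogen-bond acceptor and grows by two heavy atoms, yet the maximal response shows no change beyond the scatter, so this position has now carried an open-chain group, an aromatic group and a ring with two hetero atoms with no separation among them. No measurement shown here explains why these different groups read alike.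

The compounds shown leave open whether a group of another kind on the sulfonyl sulfur, such as a carboxylic acid at the end of a longer chain or a piperazine ring, would also stay within the scatter. They also leave open whether changes elsewhere on the shared core would shift the maximal response, since only the group on the sulfur differs here.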